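The source may report more compounds than this note shows. Statements on the series, on what has been measured and on what is new or still open speak of the compounds shown alone.

Measured so far in a functional assay on HCT-116 cells (Homo sapiens) for inhibition; on this read-out lower numbers stand for stronger inhibition and higher numbers for weaker inhibition:
Compound 1 `COc1ccc(/C=C/c2ccc3ccccc3c2)cc1`: > 5000 nM
Compound 2 `FC(F)(F)Oc1ccc(/C=C/c2ccc3ccccc3c2)cc1`: > 5000 nM

Both entries are limits, not numbers. Compound 2 is known only through its limit of > 5000 nM, and the whole picture so far is the limit of > 5000 nM in this assay, at which 2 of the 2 values shown sit.

Compound 3 `Cc1ccc(/C=C/c2ccc3ccccc3c2)cc1` follows from compound 2 by one change: methyl in place of trifluoromethoxy on an aromatic carbon, para to a large group. For the measured compounds named here, the only measured step that bears on this is a step that the two limits leave unreadable from compound 1 to compound 2, so no readable size exists to build on, and no clear shift is expected in this assay. The estimated change is a step that the limit leaves unreadable from compound 2 to compound 3, with no firm direction. Compound 3 is expected at about 6000 nM, within an estimated range of 1500 nM to 20000 nM.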

Compound 3, half-maximal inhibitory concentration: > 5000 nM
Compound 3: no number, only a limit; the forecaster's own chance of this, stated with the estimate: 80%; the middle value does not contradict the limit.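

For the compounds shown here, compound 1, compound 2 and compound 3 are all known only as limits, not numbers, so no step among them can be read: the limit of > 5000 nM in this assay, at which 3 of the 3 values shown sit. Going by these compounds, how strongly each inhibits, and how methyl, methoxy and trifluoromethoxy compare, stays open.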